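Ring size change on a bridged core: piperidine to pyrrolidine

This account rests on a few compounds, and the source may have more. Where it says the series, first, only, none or still open, it means among the compounds named here.

The series rests on a shared bridged core carrying two phenyl groups, with different amine substituents and different groups on the ring nitrogen. Compound 1 `CN1CCN(CC(=O)N2CCC3(N4CCCC4)CC(c4ccccc4)C2C(c2ccccc2)C3)CC1` gives 69100 nM in an ADME assay on L6 cells (Rattus norvegicus) for cytotoxicity; a lower number here means a stronger inhibitor, a higher number a weaker inhibitor. Compound 2 `c1ccc(C2CC3(N4CCCCC4)CCN(CCCN4CCCCC4)C2C(c2ccccc2)C3)cc1` gives 138000 nM, and compound 3 `O=C(CCN1CCCCC1)N1CCC2(N3CCCCC3)CC(c3ccccc3)C1C(c1ccccc1)C2` gives 63900 nM. Compound 2 carries the highest number of the three; its nearest neighbour is compound 1, within the scatter, and its furthest is compound 3, reached through a 2.2-fold lower number from compound 2 to compound 3 (0.33 log units; beyond the scatter).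

Compound 4 `c1ccc(C2CC3(N4CCCC4)CCN(CCCN4CCCCC4)C2C(c2ccccc2)C3)cc1` differs from compound 2 in one place: pyrrolidin-1-yl in place of piperidin-1-yl on a saturated ring carbon. Among the compounds with values here, no measured step bears directly on this change. Within the data shown here, the only step in hand, a 2.2-fold lower number from compound 2 to compound 3 (0.33 log units; beyond the scatter), concerns the substituent on the ring nitrogen, not the amine on the saturated ring carbon, and compound 1, which carries the pyrrolidin-1-yl group, differs from compound 2 in more than one place. The author therefore expects no step beyond the scatter for compound 4, estimating a 1.3-fold lower number from compound 2 to compound 4 (0.10 log units; within the scatter). Compound 4 is expected to give about 110000 nM, within a range from 50000 nM to 250000 nM.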

Compound 4, half-maximal inhibitory concentration: 28700 nM
The estimate for compound 4 lay 3.8-fold (0.58 log units) above the measured number; measured number outside the range, below it.
By their numbers in this assay, from the lowest: compound 4; then compounds 3, 1 and 2 (each within the scatter of the next, the first and the last beyond it).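

Within the data shown here, replacing piperidin-1-yl with pyrrolidin-1-yl on the saturated ring carbon gives a 4.8-fold lower number from compound 2 to compound 4 (0.68 log units; beyond the scatter) in this assay, so this position, on which no earlier step bore, does respond to the change of amine ring. With pyrrolidin-1-yl held in place, the group on the ring nitrogen also matters: 3-(piperidin-1-yl)propyl in place of ((4-methylpiperazin-1-yl)methyl)carbonyl gives a 2.4-fold lower number from compound 1 to compound 4 (0.38 log units; beyond the scatter) and so joins the earlier step of a 2.2-fold lower number from compound 2 to compound 3 (0.33 log units; beyond the scatter) in showing a response at that nitrogen. Nothing at hand accounts for either new step.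

The compounds shown leave open whether the step at the saturated ring carbon would recur with the (2-(piperidin-1-yl)ethyl)carbonyl group of compound 3 on the ring nitrogen. They also leave open how an azepan-1-yl, morpholin-4-yl or open-chain dimethylamino group would fare on that carbon.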